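Swapping methoxy for furan-2-yl on the shared core

A few compounds are considered here, and "the series" means these few. Any claim that something is new, unique, unknown or untested is made for them only; others in the source may bear on it.

Of the compounds shown here, three on a shared core have been tested in a functional assay on K562 cells (Homo sapiens), read by MTT assay, with a stated time of 3 days; on this read-out higher numbers stand for weaker inhibition and lower numbers for stronger inhibition. Compound 1 `Cc1ncnc2[nH]cc(Sc3cccs3)c12` gives 14000 nM in this assay. Compound 3 `CN(C)c1ncnc2[nH]cc(Sc3cccs3)c12` gives 3830 nM. Compound 2 `COc1ncnc2[nH]cc(Sc3cccs3)c12` reaches only the limit of the assay, > 50000 nM, and no number is known for it; this is the limit (the limit of > 50000 nM in this assay, at which 1 of the 3 values shown sits). Compound 2 thus stands as the weakest of the three, since an at least 3.5-fold higher number from compound 1 to compound 2 (0.55 log units; beyond the scatter) and an at least 13-fold lower number from compound 2 to compound 3 (1.11 log units; beyond the scatter) both lie beyond the scatter, and the second of these is a large step.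

Compound 4 `c1coc(-c2ncnc3[nH]cc(Sc4cccs4)c23)c1` carries the change (furan-2-yl in place of methoxy on an aromatic carbon). The two measured steps that start or end at compound 2 both bear on it: each shows that the group on this aromatic carbon moves the number strongly, and that methoxy gives the highest number of the three groups tried. Furan-2-yl is a ring rather than a small chain, so the size of the step cannot be read off directly; still, the pattern from compound 2 to compounds 1 and 3 makes a lower number the more likely direction. Compound 4 is therefore expected to sit near compound 1, at about 9000 nM, with a plausible range from 2000 nM to 45000 nM, so that the estimated step is an at least 5.5-fold lower number from compound 2 to compound 4 (0.74 log units; beyond the scatter).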

Compound 4, half-maximal inhibitory concentration: 4260 nM
The estimate for compound 4 lay 2.1-fold (0.32 log units) above the measured number; measured number inside the range.
By their numbers in this assay, from the lowest: compounds 3 and 4 (each within the scatter of the next); then compound 1. At a limit, above all of these: compound 2.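

In this assay, a whole aromatic ring on this carbon of the shared core serves as well as dimethylamino, which the opening compounds could not show, with a 1.1-fold higher number from compound 3 to compound 4 (0.05 log units; within the scatter), and it also goes clearly past methyl, with a 3.3-fold lower number from compound 1 to compound 4 (0.52 log units; beyond the scatter). Methoxy and furan-2-yl each bring one oxygen, one hydrogen-bond acceptor and no donor, yet the change between them gives an at least 11-fold lower number from compound 2 to compound 4 (1.06 log units; beyond the scatter), so among these compounds the acceptor and donor counts alone do not set the number at this position. That step is only a bound, since compound 2 stands at a limit of the assay: the limit of > 50000 nM in this assay, at which 1 of the 4 values shown sits.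

The compounds shown leave open whether the level shared by compounds 3 and 4 belongs to furan-2-yl itself or would also be reached by another ring here, such as phenyl, furan-3-yl or morpholine. They also leave open whether a primary amine, a carboxylic acid or a longer alkyl chain on this carbon would give a number in line with that level or one closer to that of compound 1.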